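This account rests on a few compounds, and the source may have more. Where it says the series, first, only, none or still open, it means among the compounds named here.

The study centres on an assay on HEK293 cells for displacement of a labelled ligand from B1 bradykinin receptor (Homo sapiens), read by scintillation counting; on this read-out lower numbers stand for stronger inhibition and higher numbers for weaker inhibition. Compound 1 `COc1cc(C)c(S(=O)(=O)N(C)CCOCC(=O)N2CCN(CCN(C)C)CC2)c(C)c1` gives 106 nM in this assay. Compound 2 `COc1cc(C)c(S(=O)(=O)N(C)CCOCC(=O)N2CCC(C(C)(C)CN(C)C)CC2)c(C)c1` gives 10 nM in this assay, the lowest of the two numbers recorded so far, and the number for compound 1 lies above it by a gap that is beyond the usual scatter of such measurements.

Compound 3 `COc1cc(C)c(S(=O)(=O)N(C)CCOCC(=O)N2CCC(C(O)CN(C)C)CC2)c(C)c1` has not yet been measured in this assay. It differs from compound 2 in a single place: 2-(dimethylamino)-1-hydroxyethyl in place of 1-((dimethylamino)methyl)-1-methylethyl on a saturated ring carbon. Among the measured compounds shown here, no measured pair in this set shows a change of this kind, so there is no measured step to lean on. On that footing a modest shift toward a higher number is expected, somewhat beyond the scatter, and the step is expected to be a 3.0-fold higher number from compound 2 to compound 3 (0.48 log units; beyond the scatter). Compound 3 is thus expected to give 30 nM in this assay, with a likely range from 7 nM to 120 nM.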

Compound 3, inhibition constant: 30 nM
The estimate for compound 3 equals the measured number at the digits printed; measured number inside the range.
By their numbers in this assay, from the lowest: compound 2; then compound 3; then compound 1.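

Among the compounds shown here, this is the first measured change at the saturated ring carbon three ring bonds from the ring nitrogen, and it shows that the number in this assay responds to the group held there. Exchanging 1-((dimethylamino)methyl)-1-methylethyl for 2-(dimethylamino)-1-hydroxyethyl gives a 3.0-fold higher number from compound 2 to compound 3 (0.48 log units; beyond the scatter), a modest step, even though the dimethylamino end is present in both groups. The exchange also brings in a hydrogen-bond donor and removes carbon in the same step, so the result cannot be assigned to either alteration, and nothing available explains the shift.

The compounds shown leave open how a methoxy group, a fluorine or a primary amine would read in place of the hydroxyl. They also leave open what a longer chain leading to the dimethylamino group would do at this position.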